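The compounds below may be only part of what the source reports. "The series", "measured", "known", "first", "only" and "open" are said of these compounds alone.

Measured so far:
Compound 1 `CCNC1CC(=O)OC1C(O)C(=O)NC(CC(C)C)C1Cc2cccc(O)c2C(=O)O1`: 11000 ug/mL
Compound 2 `CCCCNC1CC(=O)OC1C(O)C(=O)NC(CC(C)C)C1Cc2cccc(O)c2C(=O)O1`: 370 ug/mL

Among the compounds with values here, in a physicochemical assay for solubility, in phosphate buffer (a higher number here means a more soluble compound, a lower number a less soluble compound), compound 2 stands lowest of the two numbers; its only neighbour, compound 1, gives 11000 ug/mL. Compound 3 `CCCCCNC1CC(=O)OC1C(O)C(=O)NC(CC(C)C)C1Cc2cccc(O)c2C(=O)O1` differs from compound 2 by methyl in place of hydrogen on a saturated chain carbon, four bonds along the chain from an amine nitrogen. Within the data shown here, the one step that bears on this is a 30-fold lower number from compound 1 to compound 2 (1.47 log units; beyond the scatter), a large drop for a longer chain at the same amine nitrogen. Compound 3 is therefore expected to show a smaller drop, estimated as a 3.1-fold lower number from compound 2 to compound 3 (0.49 log units; beyond the scatter). The estimate for compound 3 is 120 ug/mL, with a range of 30 ug/mL to 400 ug/mL.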

Compound 3, solubility: 330 ug/mL
Compound 3: middle estimate off by 2.8-fold (0.44 log units), on the low side, within the range that was stated.
By their numbers in this assay, from the lowest: compounds 3 and 2 (each within the scatter of the next); then compound 1.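

In this assay methyl in place of hydrogen, four bonds along the chain from an amine nitrogen, gives a 1.1-fold lower number from compound 2 to compound 3 (0.05 log units; within the scatter) and so separates compound 2 and compound 3 by no more than the scatter. Propyl in place of hydrogen, two bonds along the chain from an amine nitrogen, gives a 33-fold lower number from compound 1 to compound 3 (1.52 log units; beyond the scatter) as a large step, much like the one already seen with ethyl at that place. Nothing available explains why the second extension differs from the first. On these data alone, whether a longer chain would stay level with compound 3 remains open, as does how a chain carrying a hydroxyl group or a carboxylic acid would compare.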